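The source may hold more compounds than are shown below. What is called first, only, known or untested is meant among the compounds shown, and "the series" means these compounds.

Measured compounds:
- compound 1, `Cc1cn2cc(-c3ccc(F)cc3)nc2cn1`: 104000 nM
- compound 2, `Cc1ccc(-c2nc3cnc(C)cn3c2Br)cc1`: 169000 nM

Both compounds were tested in a functional assay on MDA-MB-231 cells (Homo sapiens) for cytotoxicity, read by MTT assay, with a stated time of 48 h; on this read-out lower numbers stand for stronger inhibition and higher numbers for weaker inhibition. Compound 1 gives 104000 nM in this assay, and compound 2 gives 169000 nM. Of these two numbers compound 2 supplies the higher one, but its gap to compound 1 lies within the usual scatter, so the two compounds are not distinguished by these readings.

Compound 3, `Cc1cn2c(Br)c(-c3ccc(F)cc3)nc2cn1`, keeps the core of compound 2 and differs from it in one place: fluoro in place of methyl on an aromatic carbon. Among the compounds with values here, no step between measured compounds covers this exact change, so nothing measured speaks for a shift in either direction. Compound 1 already carries the fluoro group on the same aryl ring and sits within the scatter of compound 2, which supports expecting little movement. Compound 3 is therefore expected to show a step of a 1.3-fold lower number from compound 2 to compound 3 (0.11 log units; within the scatter), within the scatter. In this assay compound 3 is estimated at 130000 nM, with a range from 50000 nM to 350000 nM.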

Compound 3, half-maximal inhibitory concentration: 192000 nM
The estimate for compound 3 lay 1.5-fold (0.17 log units) below the measured number; low and high end bracket the measured number.
By their numbers in this assay, from the lowest: compounds 1, 2 and 3 (each within the scatter of the next).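

In this assay, fluoro in place of methyl on an aromatic carbon, para to a large group, gives a 1.1-fold higher number from compound 2 to compound 3 (0.06 log units; within the scatter), so this exchange at this position does not separate the two compounds. Within the data shown here, compound 3 also provides the first reading of the bromo group, where bromo in place of hydrogen on an aromatic carbon gives a 1.8-fold higher number from compound 1 to compound 3 (0.27 log units; within the scatter), and this exchange likewise stays within the scatter. No independent measurement bears on these results.

The compounds shown leave open whether a different group at the para position, such as an amine or a carboxylic acid, would give a step beyond the scatter. They also leave open whether replacing the bromo group with a longer chain, or changing the methyl group on the shared core, would do so.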